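Replacing the Pyridyl Cap on the Piperazine Amide

This account rests on a few compounds, and the source may have more. Where it says the series, first, only, none or still open, it means among the compounds named here.

Measured compounds:
Compound 1, `CC#CC(CC(=O)O)c1ccc(OCc2ccc(C(=O)N3CCN(C4CCCCC4)CC3)s2)cc1`: 820 nM
Compound 2, `CC#CC(CC(=O)O)c1ccc(OCc2ccc(C(=O)N3CCN(c4ccccn4)CC3)s2)cc1`: 138 nM

In a functional assay on HEK293 cells for agonist activity at Free fatty acid receptor 1 (Homo sapiens), read by fluorescence and calcium flux (a higher number here means that more compound is needed for the effect, a lower number that less compound is needed), compound 1 gives 820 nM, while compound 2 gives 138 nM. Within the data shown here, compound 2 holds the lower of the two numbers; the only measured step is a 5.9-fold lower number from compound 1 to compound 2 (0.77 log units; beyond the scatter), a modest change brought about by pyridin-2-yl in place of cyclohexyl on an amine nitrogen in a ring.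

Compound 3, `CC#CC(CC(=O)O)c1ccc(OCc2ccc(C(=O)N3CCN(c4ccccc4[N+](=O)[O-])CC3)s2)cc1`, differs from compound 2 by 2-nitrophenyl in place of pyridin-2-yl on an amine nitrogen in a ring. The earlier step bears on this only loosely: it exchanged a saturated ring for an aromatic one, whereas here one six-membered aromatic ring replaces another at the same position. Among the measured compounds shown here, no measured pair tests 2-nitrophenyl directly. The expectation is therefore a small step in this assay, if any, with a slight rise in the number considered more likely than a fall. Compound 3 is expected to give 220 nM, within 70 nM to 700 nM. The estimated step is a 1.6-fold higher number from compound 2 to compound 3 (0.20 log units; within the scatter).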

Compound 3, half-maximal effective concentration: 94 nM
Estimate against measurement, compound 3: 2.3-fold (0.37 log units) above; the range from low to high includes it.
By their numbers in this assay, from the lowest: compounds 3 and 2 (each within the scatter of the next); then compound 1.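

In this assay the exchange of pyridin-2-yl for 2-nitrophenyl gives a 1.5-fold lower number from compound 2 to compound 3 (0.17 log units; within the scatter) at this amine nitrogen. The hetero atom of the pyridin-2-yl ring is therefore not needed to keep the number in this range, since a six-membered aromatic ring of carbon only, carrying a nitro group, does not differ from it beyond the scatter. Set against cyclohexyl, the same group gives an 8.7-fold lower number from compound 1 to compound 3 (0.94 log units; beyond the scatter) and so the second aromatic group also stands apart from the saturated ring, though only these three groups can be compared here. Nothing at hand accounts for these numbers. As far as these compounds go, it remains open whether the nitro group contributes at all, as plain phenyl, 2-methoxyphenyl or 2-cyanophenyl would show. Also open, from the compounds shown here alone, is how a benzyl group or a short alkyl chain on the same nitrogen would compare.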